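Replacing isopropyl with methoxy on the sulfonamide aryl ring

The source may report more compounds than this note shows. Statements on the series, on what has been measured and on what is new or still open speak of the compounds shown alone.

The three measured compounds share one core and differ only in the group that sits on the sulfonyl-bearing aromatic ring. Compound 1 `CN(/N=C/c1cnn2ccc(C#N)cc12)S(=O)(=O)c1cc([N+](=O)[O-])ccc1F` carries fluoro there and in an assay on isolated protein for inhibition of phosphatidylinositol 4,5-bisphosphate 3-kinase catalytic subunit beta isoform (Homo sapiens), read by 33P incorporation, with a stated time of 60 min (a lower number here means a stronger inhibitor, a higher number a weaker inhibitor), compound 1 gives 44 nM. Compound 2 `CN(C)c1ccc([N+](=O)[O-])cc1S(=O)(=O)N(C)/N=C/c1cnn2ccc(C#N)cc12` carries dimethylamino, and in this assay compound 2 gives 44 nM; the step of no change at the digits printed from compound 1 to compound 2 (within the scatter). Compound 3 `CC(C)c1ccc([N+](=O)[O-])cc1S(=O)(=O)N(C)/N=C/c1cnn2ccc(C#N)cc12` carries isopropyl, and in this assay compound 3 gives 300 nM, the highest of the three numbers and the weakest inhibitor shown, since a 6.8-fold higher number from compound 1 to compound 3 (0.83 log units; beyond the scatter) and a 6.8-fold higher number from compound 2 to compound 3 (0.83 log units; beyond the scatter).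

Compound 4 `COc1ccc([N+](=O)[O-])cc1S(=O)(=O)N(C)/N=C/c1cnn2ccc(C#N)cc12` is the next variation: methoxy in place of isopropyl on an aromatic carbon. The two steps that bear on this, from compound 1 and from compound 2 to compound 3, were both of modest size and both went in the same direction, so moving away from isopropyl is expected to lower the number in this assay again by a modest amount, as a 4.3-fold lower number from compound 3 to compound 4 (0.63 log units; beyond the scatter). For compound 4 in this assay the estimate is 70 nM, with a range from 30 nM to 180 nM.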

Compound 4, half-maximal inhibitory concentration: 63 nM
For compound 4 the middle estimate is 1.1-fold (0.05 log units) above the measured one, within the range that was stated.
By their numbers in this assay, from the lowest: compounds 1, 2 and 4 (each within the scatter of the next); then compound 3.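

With methoxy as a fourth group at this position, compound 3 stands apart in this assay: leaving isopropyl restores a low number (a 4.8-fold lower number from compound 3 to compound 4 (0.68 log units; beyond the scatter)). Among the compounds shown here, the steps to methoxy from the other two groups stay within the scatter (a 1.4-fold higher number from compound 1 to compound 4 (0.16 log units; within the scatter); a 1.4-fold higher number from compound 2 to compound 4 (0.16 log units; within the scatter)), so methoxy, fluoro and dimethylamino cannot be told apart here, and isopropyl is the only one of the four groups that goes with a weaker inhibitor. No measurement among the available data gives a reason for this difference.

From the compounds shown here alone, it remains open whether an ethoxy group or a hydroxyl would stay with methoxy, or whether a longer chain such as propoxy would move the number as isopropyl does. A carboxylic acid or a primary amine at this position also remains untested by the compounds shown.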